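The compounds below may be only part of what the source reports. "The series", "measured", "known", "first", "only" and "open" are said of these compounds alone.

Compound 1 `NC(=O)CCCC/C=C(\c1ccccc1)c1cccnc1` is the weakest inhibitor among the three measured compounds. In an assay (Equus caballus) for inhibition of Thromboxane-A synthase (Homo sapiens), using microsomes (on this read-out higher numbers stand for weaker inhibition and lower numbers for stronger inhibition), compound 1 gives 400 nM, the highest of the three numbers. Compound 2 `O=C(O)CCCC/C=C(\c1cccnc1)c1cccc(Br)c1` gives 180 nM in this assay, a lower number beyond the scatter, and compound 3 `O=C(O)CCCC/C=C(/c1cccnc1)c1ccsc1` gives 62 nM in this assay, the lowest of the three and furthest from compound 1. Compound 4 `CCOC(=O)CCCC/C=C(\c1ccccc1)c1cccnc1` differs from compound 1 in one place: ethoxy in place of amino on a carbonyl carbon. For the measured compounds named here, neither compound 1 nor compound 4 carries the acid found in compound 2 and compound 3, and no measured pair shows this exact change. The step of a 1.6-fold higher number from compound 1 to compound 4 (0.21 log units; within the scatter) in this assay is expected to be modest, toward a somewhat higher number. Compound 4 is estimated at 650 nM, with a range from 200 nM to 2200 nM.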

Compound 4, half-maximal inhibitory concentration: 600 nM
Compound 4: middle estimate off by 1.1-fold (0.03 log units), on the high side; the measured number falls inside the stated range.
By their numbers in this assay, from the lowest: compound 3; then compound 2; then compounds 1 and 4 (each within the scatter of the next).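

In this assay, putting ethoxy in place of amino on a carbonyl carbon gives a 1.5-fold higher number from compound 1 to compound 4 (0.18 log units; within the scatter) and so leaves the two groups indistinguishable at this position. The change from carbamoyl to ethoxycarbonyl adds heavy atoms and removes the hydrogen-bond donor, yet the numbers stay within the scatter of each other. No measurement given here accounts for this result. Still open, as far as these compounds go, is how a carboxylic acid, a methoxy group or a longer alkoxy chain on this carbonyl carbon would read on the core of compound 1.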